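The compounds below may be only part of what the source reports. "The series", "measured", "known", "first", "only" and "open" are said of these compounds alone.

Compound 1 `CC(C)c1cccc(C(C)C)c1NC(=O)NCC1(c2ccccc2)CCCCC1`: 21 nM
Compound 2 `Cc1ccccc1NC(=O)NCC1(c2ccccc2)CCCCC1`: 640 nM
Compound 3 `CC(C)c1ccccc1NC(=O)NCC1(c2ccccc2)CCCCC1`: 390 nM

These three compounds were tested in an assay on microsomes from intestine for inhibition of acyl-CoA:cholesterol acyltransferase (Oryctolagus cuniculus); a higher number here means a weaker inhibitor, a lower number a stronger inhibitor. Compound 1 gives 21 nM, compound 2 gives 640 nM and compound 3 gives 390 nM. Among the three, compound 3 stands second highest: its nearest neighbour is compound 2, a 1.6-fold lower number from compound 2 to compound 3 (0.22 log units; within the scatter), a gap within the scatter, so no order can be read between them; its furthest is compound 1, a 19-fold higher number from compound 1 to compound 3 (1.27 log units; beyond the scatter).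

Compound 4 `Cc1cccc(C(C)C)c1NC(=O)NCC1(c2ccccc2)CCCCC1` is the next step from compound 3. The change is methyl in place of hydrogen on an aromatic carbon. It fills the aromatic carbon that carries hydrogen in compound 3 and an isopropyl group in compound 1, so the step that bears on it most is a 19-fold higher number from compound 1 to compound 3 (1.27 log units; beyond the scatter), a large one. The comparison of compound 2 with compound 3, a 1.6-fold lower number from compound 2 to compound 3 (0.22 log units; within the scatter), shows that exchanging a methyl for an isopropyl at an aromatic carbon moved the number only within the scatter. Taken together, a methyl entering at that position in compound 4 is expected to bring the number down clearly, though perhaps not as far as the isopropyl in compound 1 did: the step expected is a 4.9-fold lower number from compound 3 to compound 4 (0.69 log units; beyond the scatter).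

For compound 4 the estimate in this assay is 80 nM, with a range from 30 nM to 250 nM.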

Compound 4, half-maximal inhibitory concentration: 58 nM
Beside the measured number, compound 4's estimate is 1.4-fold (0.14 log units) above it; measured number inside the range.
By their numbers in this assay, from the lowest: compound 1; then compound 4; then compounds 3 and 2 (each within the scatter of the next).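

In this assay, the position does not need an isopropyl group to matter: a methyl alone gives a 6.7-fold lower number from compound 3 to compound 4 (0.83 log units; beyond the scatter), and the isopropyl group entering on the core of compound 2 gives an 11-fold lower number from compound 2 to compound 4 (1.04 log units; beyond the scatter). The size of the group there also now shows, since a 2.8-fold higher number from compound 1 to compound 4 (0.44 log units; beyond the scatter) lies beyond the scatter, whereas the exchange of methyl for isopropyl between compound 2 and compound 3 stayed within it, although these two steps cannot be told apart: the same change on two cores in this assay, a 1.6-fold lower number (0.22 log units; within the scatter) from compound 2 to compound 3 and a 2.8-fold lower number (0.44 log units; beyond the scatter) from compound 4 to compound 1, 1.7-fold (0.23 log units) apart, within the scatter of two such steps. Removing an isopropyl group costs a similar amount whether the group left on the other side of the ring is an isopropyl or a methyl: the same change on two cores in this assay, a 19-fold higher number (1.27 log units; beyond the scatter) from compound 1 to compound 3 and an 11-fold higher number (1.04 log units; beyond the scatter) from compound 4 to compound 2, 1.7-fold (0.23 log units) apart, within the scatter of two such steps.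

The compounds shown leave open how an ethyl group, a tert-butyl group, a methoxy group or a chlorine atom would behave at this position, so the trend is defined only by hydrogen, methyl and isopropyl. They also leave open whether these steps would hold on a core other than the shared one, or in any setting other than this assay.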